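Does a Chlorophenyl Amide Match the Methoxyphenyl Amide?

The compounds below may be only part of what the source reports. "The series", "measured", "known", "first", "only" and "open" are said of these compounds alone.

Going by the values given here, compound 2 `COc1cccc(C(=O)Nc2c(C(O)(C(F)(F)F)C(F)(F)F)ccc3ccccc23)c1` gives 185 nM in an assay on LtK cells with ATP-sensitive inward rectifier potassium channel 11 (Homo sapiens) as the target (on this read-out higher numbers stand for an effect only at larger amounts of compound and lower numbers for an effect already at smaller amounts), the lowest of the two numbers so far, while compound 1 `O=C(NCCCCCCCl)Nc1c(C(O)(C(F)(F)F)C(F)(F)F)ccc2ccccc12` gives 4840 nM in this assay. Among the compounds with values here, the single measured step, a 26-fold lower number from compound 1 to compound 2 (1.42 log units; beyond the scatter), replaced the entire group on the carbonyl carbon and was large. Compound 3 `O=C(Nc1c(C(O)(C(F)(F)F)C(F)(F)F)ccc2ccccc12)c1ccc(Cl)cc1` differs from compound 2 by 4-chlorophenyl in place of 3-methoxyphenyl on a carbonyl carbon. Within the data shown here, no measured step compares one aromatic ring with another on that carbonyl carbon, so a change within the scatter is expected, namely a 1.1-fold higher number from compound 2 to compound 3 (0.03 log units; within the scatter). Compound 3 is therefore estimated at 200 nM, with a range from 60 nM to 700 nM.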

Compound 3, half-maximal effective concentration: 570 nM
Beside the measured number, compound 3's estimate is 2.9-fold (0.45 log units) below it; the measured number falls inside the stated range.
By their numbers in this assay, from the lowest: compound 2; then compound 3; then compound 1.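

The aromatic groups on this carbonyl carbon are not interchangeable: 4-chlorophenyl in place of 3-methoxyphenyl gives a 3.1-fold higher number from compound 2 to compound 3 (0.49 log units; beyond the scatter). Even so, 4-chlorophenyl keeps part of the gain over (6-chlorohexyl)amino, with an 8.5-fold lower number from compound 1 to compound 3 (0.93 log units; beyond the scatter). Nothing available gives a reason for the difference between the two aromatic groups. Since the identity and the place of the ring's substituent change together, the compounds shown cannot separate the two. From the compounds shown here alone, how a phenyl ring carrying an amine or a carboxylic acid would read on this carbonyl carbon also remains open.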